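The source may report more compounds than this note shows. Statements on the series, on what has been measured and on what is new or still open speak of the compounds shown alone.

Values measured in a functional assay, read by spectrophotometry, with a stated time of 6 min; on this read-out higher numbers stand for weaker inhibition and lower numbers for stronger inhibition:

- compound 1 `CCOc1cc(OC)c(Br)cc1C(C)=O`: 36000000 nM
- compound 2 `CCCCCCCCOc1cc(OC)c(Br)cc1C(C)=O`: 32000000 nM
- compound 3 `CCOc1cc(OC)ccc1C(C)=O`: 37700000 nM

All three numbers lie within the usual scatter of one another, so compound 3, at 37700000 nM, stands level with compound 1 and compound 2 on this evidence. The next compound to be measured is compound 4 `CCCCCCOc1cc(OC)ccc1C(C)=O`. It differs from compound 3 by butyl in place of hydrogen on a saturated chain carbon, two bonds along the chain from an oxygen on an aromatic ring, which is butyl in place of hydrogen on a saturated chain carbon, two bonds along the chain from an oxygen on an aromatic ring.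

For the measured compounds named here, the closest precedent is hexyl in place of hydrogen at that same place, which gave a 1.1-fold lower number from compound 1 to compound 2 (0.05 log units; within the scatter). That step was made on a core carrying bromo. Hydrogen in place of bromo on an aromatic carbon gave a 1.0-fold higher number from compound 1 to compound 3 (0.02 log units; within the scatter). Both steps stayed within the scatter, so no change beyond the scatter is expected in this assay. The expected step is a 1.1-fold lower number from compound 3 to compound 4 (0.04 log units; within the scatter). Compound 4 is estimated at 34000000 nM, with an expected range from 20000000 nM to 56000000 nM.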

Compound 4, half-maximal inhibitory concentration: 42100000 nM
Compound 4: the middle estimate sits 1.2-fold (0.09 log units) below what was measured, and the stated range covers the measured number.
By their numbers in this assay, from the lowest: compounds 2, 1, 3 and 4 (each within the scatter of the next).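

In this assay, butyl in place of hydrogen on a saturated chain carbon, two bonds along the chain from an oxygen on an aromatic ring, gives a 1.1-fold higher number from compound 3 to compound 4 (0.05 log units; within the scatter). The earlier compounds shown here showed a chain change at this place only on the core carrying bromo, whereas this step shows that a chain change on the core without bromo also stays within the scatter. So at this place, neither the hexyl step on one core nor the butyl step on the other separates the compounds in this read-out, and nothing available explains this result.

The compounds shown leave open whether a group other than a plain saturated chain, such as an amine or a carboxylic acid at the end of the chain, would give a step beyond the scatter. They also leave open whether hexyl or a longer chain entering at this place on the core without bromo would do so.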